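Swapping a Bromo for Two Fluoro Groups on the Benzyl Arm

The source may report more compounds than this note shows. Statements on the series, on what has been measured and on what is new or still open speak of the compounds shown alone.

Compound 2, `COC(=O)c1ccc(NCc2cncn2Cc2ccc(Br)cc2)cc1-c1ccccc1`, was tested in a toxicity assay on NIH3T3 cells (Mus musculus) for cytotoxicity, read by resazurin assay; a lower number here means that less compound is needed, a higher number that more compound is needed for the effect. In this assay compound 2 gives > 10000 nM, which is a limit of the assay rather than a number, namely (the limit of > 10000 nM in this assay, at which 1 of the 2 values shown sits). Compound 1, `COC(=O)c1ccc(NCc2cncn2Cc2ccc(-c3ccccc3)cc2)cc1-c1ccccc1`, shares the core and carries a phenyl where compound 2 carries a bromo on an aromatic carbon. In this assay compound 1 gives > 1000 nM, again a limit rather than a number, namely (the limit of > 1000 nM in this assay, at which 1 of the 2 values shown sits). Going by the values given here, the one measured step, a step that the two limits leave unreadable from compound 1 to compound 2, therefore has no readable size. Compound 3, `COC(=O)c1ccc(NCc2cncn2Cc2ccc(F)cc2F)cc1-c1ccccc1`, is the next compound to be measured; its difference from compound 2 is 2,4-difluorophenyl in place of 4-bromophenyl on a saturated chain carbon bound to an aromatic nitrogen. Among the compounds with values here, no measured step addresses a fluoro for bromo exchange, and the only step present is unreadable, so no direction can be drawn from the data. Both measured compounds sit at limits. For compound 3 the expected step of a number no higher from compound 2 to compound 3 (the limit leaves the size open) is none beyond the scatter. Compound 3 is thus estimated at 10000 nM, with a range from 3000 nM to 30000 nM, and is most likely to be reported again only as a limit.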

Compound 3, half-maximal effective concentration: > 1000 nM
Compound 3 was reported as a limit (the forecaster's own chance of this, stated with the estimate: 70%); the middle value lies beyond the limit too.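

Going by these compounds alone, compound 1, compound 2 and compound 3 all stand only as limits in this assay, not as numbers, so no step among them can be read. The compounds shown leave open the concentration at which each becomes toxic to these cells, and whether 4-phenylphenyl, 4-bromophenyl or 2,4-difluorophenyl makes any difference.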